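Three measured compounds, one awaited, in a cell tolerance assay

The compounds below may be only part of what the source reports. "The series", "measured", "known", "first", "only" and "open" are said of these compounds alone.

Compound 1 `Cc1ccc(-c2nn(-c3ccccc3)cc2CNc2ccc(Br)cc2)cc1` gives in an ADME assay on MDBK cells (Bos taurus) for cytotoxicity, read by MTT assay, with a stated time of 72 h (a higher number here means that more compound is tolerated, a lower number that less compound is tolerated), only a limit, > 100000 nM.
Compound 2 `Cc1ccc(-c2nn(-c3ccccc3)cc2CNc2ccc(C(F)(F)F)cc2)cc1` gives in this assay only a limit, > 100000 nM.
Compound 3 `Brc1ccc(NCc2cn(-c3ccccc3)nc2-c2ccc(Br)cc2)cc1` gives in this assay only a limit, > 100000 nM.

Compound 2 arises from compound 1 by one change, (trifluoromethyl in place of bromo on an aromatic carbon), and in this assay this gave a step that the two limits leave unreadable from compound 1 to compound 2. The core of compound 3 differs from that of compound 1 by bromo in place of methyl on an aromatic carbon, and in this assay this gave a step that the two limits leave unreadable from compound 1 to compound 3. The same change is now made again: compound 4 `FC(F)(F)c1ccc(-c2nn(-c3ccccc3)cc2CNc2ccc(Br)cc2)cc1` arises from compound 3 by trifluoromethyl in place of bromo on an aromatic carbon, the place of the change reading the same in both pairs.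

Among the compounds with values here, nothing among the measured compounds shows a readable step, because of the limit of > 100000 nM in this assay, at which 3 of the 3 values shown sit. In this assay compound 4 is therefore expected to give a number no higher from compound 3 to compound 4 (the limit leaves the size open) beside the earlier step that the two limits leave unreadable from compound 1 to compound 2, most likely again as a limit rather than a number. The estimate for compound 4 is 100000 nM, with a range from 50000 nM to 300000 nM.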

Compound 4, half-maximal cytotoxic concentration: 64000 nM
For compound 4 the middle estimate is 1.6-fold (0.19 log units) above the measured one, and the stated range covers the measured number.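

In this assay, putting trifluoromethyl in place of bromo on the core of compound 3 gave an at least 1.5-fold lower number from compound 3 to compound 4 (0.19 log units; that floor lies within the scatter), and the difference of trifluoromethyl in place of methyl gave an at least 1.5-fold lower number from compound 1 to compound 4 (0.19 log units; that floor lies within the scatter). Within the data shown here, both figures are only floors within the scatter, so they show that compound 4 is the one compound here with a number rather than a limit, but not that either change truly lowers the tolerated concentration. Carrying the change from one core to the other cannot be judged, because the steps among compounds 1, 2 and 3 cannot be read and the step on the core of compound 1 gives nothing to set the new one against: the limit of > 100000 nM in this assay, at which 3 of the 4 values shown sit.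

The compounds shown leave open whether an amine, a carboxylic acid or a longer chain in the place of the change would give a number in this assay. They also leave open how far the true values of compounds 1, 2 and 3 lie from their limits, and thus how large any of these steps really is.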